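Crown ether esters against SW1573 cells: from cinnamate to acetate

The source may report more compounds than this note shows. Statements on the series, on what has been measured and on what is new or still open speak of the compounds shown alone.

Compound 1, `O=C(/C=C/c1ccccc1)OCC1COCCOCCOCCOCCOCCO1`, gives 48000 nM in a functional assay on SW1573 cells (Homo sapiens) for inhibition, read by sulforhodamine B assay, with a stated time of 48 h; on this read-out lower numbers stand for stronger inhibition of growth and higher numbers for weaker inhibition of growth.
Compound 2, `O=C(CCCCC1CCCCC1)OCC1COCCOCCOCCOCCO1`, gives > 100000 nM in this assay, a limit of the assay rather than a number.

Among the compounds with values here, of the two compounds measured in this assay, compound 1 is the only one with a number; compound 2 sits at a limit, and that is all that is known of compound 2 (the limit of > 100000 nM in this assay, at which 1 of the 2 values shown sits). Compound 1 therefore stands as the sole reference point, and its own value already lies far from strong inhibition of growth.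

Compound 3, `CC(=O)OCC1COCCOCCOCCOCCOCCO1`, is not yet measured. It differs from compound 1 in one place, (methyl in place of 2-phenylethenyl on a carbonyl carbon). Within the data shown here, the shared core is unchanged, and no step between two measured compounds of this kind is available to size the change, so the expectation rests on compound 1 alone together with the limit seen for compound 2.

Compound 3 is expected to inhibit growth more weakly than compound 1, with an estimated step of a 3.1-fold higher number from compound 1 to compound 3 (0.49 log units; beyond the scatter), beyond the scatter. The estimate for compound 3 in this assay is 150000 nM, in a range from 60000 nM to 400000 nM, with a real chance that only a limit is reported.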

Compound 3, concentration for 50% growth inhibition: > 100000 nM
Compound 3: only a limit was reported; the forecaster's own chance of this, stated with the estimate: 60%; the middle value is on the limit's open side.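

In this assay compound 3 gives > 100000 nM, which is a limit and not a number. Within the data shown here, replacing 2-phenylethenyl with methyl on a carbonyl carbon, with the shared core unchanged, gives an at least 2.0-fold higher number from compound 1 to compound 3 (0.31 log units; beyond the scatter), the first step that can be sized and the first sign that the group at this position matters for growth inhibition. Compound 1 keeps the only number in the series, and only a lower bound can be placed on the loss, while the limit now accounts for most of the values: the limit of > 100000 nM in this assay, at which 2 of the 3 values shown sit.

The single change removes an aromatic ring and a double bond together, along with most of the heavy atoms of the group, so the compounds shown cannot tell which of these features goes with the activity of compound 1. A 2-phenylethyl group, which would keep the ring without the double bond, or a longer straight chain in the same place would begin to separate these features, and a substituent such as an amine on the phenyl ring would test whether the number of compound 1 can be improved at all.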